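The source may report more compounds than this note shows. Statements on the series, on what has been measured and on what is new or still open speak of the compounds shown alone.

Measured so far in a functional assay on MDA-MB-231 cells (Homo sapiens) for cytotoxicity, read by MTT assay, with a stated time of 72 h; a higher number here means a weaker inhibitor, a lower number a stronger inhibitor:
compound 1 `O=C(CN1CCN(c2nnc(Cc3ccncc3)c3ccccc23)CC1)Nc1ccc(F)c(Cl)c1` — 4 nM
compound 2 `Cc1ccc(NC(=O)CN2CCN(c3nnc(Cc4ccccc4)c4ccccc34)CC2)c(C)c1` — 181000 nM
compound 3 `O=C(CN1CCN(c2nnc(Cc3ccccc3)c3ccccc23)CC1)Nc1ccc(F)c(C(F)(F)F)c1` — 760 nM

Compound 3 stands second highest of the three numbers: its nearest neighbour is compound 1, which gives a number far lower, and its furthest is compound 2, far higher. Going by the values given here, the one step measured within this set, a 240-fold lower number from compound 2 to compound 3 (2.38 log units; beyond the scatter), shows that the aryl group on the amide-type nitrogen moves the number a great deal.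

Compound 4 `O=C(CN1CCN(c2nnc(Cc3ccccc3)c3ccccc23)CC1)Nc1ccc(F)c(Cl)c1` is not yet measured. It differs from compound 3 in one place: chloro in place of trifluoromethyl on an aromatic carbon. Among the compounds with values here, no measured step covers this exact change; the only compound carrying the 3-chloro-4-fluorophenyl group is compound 1, and it differs from compound 4 elsewhere in the structure, so its value can only be taken as a hint. Given the large effect of the anilide aryl seen in a 240-fold lower number from compound 2 to compound 3 (2.38 log units; beyond the scatter) and the low number of compound 1 with the same aryl, the step of a 5.1-fold lower number from compound 3 to compound 4 (0.70 log units; beyond the scatter) is expected to run downward, beyond the scatter. The value expected for compound 4 is 150 nM, with a range of 20 nM to 1200 nM.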

Compound 4, half-maximal inhibitory concentration: 7360 nM
Compound 4: the middle estimate sits 49-fold (1.69 log units) below what was measured, and the stated range ends below it.
By their numbers in this assay, from the lowest: compound 1; then compound 3; then compound 4; then compound 2.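

In this assay the trifluoromethyl group on this aromatic carbon, ortho to a fluoro group, gives the lower number: chloro in its place brings a 9.7-fold higher number from compound 3 to compound 4 (0.99 log units; beyond the scatter) and thus a modest rise. The 3-chloro-4-fluorophenyl group still reads lower than 2,4-dimethylphenyl on the amide-type nitrogen, with a 25-fold lower number from compound 2 to compound 4 (1.39 log units; beyond the scatter) as the step. The largest change lies outside this position, since phenyl in place of pyridin-4-yl gives a 1800-fold higher number from compound 1 to compound 4 (3.26 log units; beyond the scatter) and the 3-chloro-4-fluorophenyl group alone therefore does not carry the low value of compound 1 (4 nM).

Open, going by these compounds, are the effect of a methoxy group or an amine on this aromatic carbon and whether trifluoromethyl keeps its advantage over chloro alongside pyridin-4-yl. No evidence at hand accounts for any of these steps.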